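Benzyl series: from methoxymethoxy to chloro

A few compounds are considered here, and "the series" means these few. Any claim that something is new, unique, unknown or untested is made for them only; others in the source may bear on it.

Values in a functional assay on HL-60 cells (Homo sapiens) for cytotoxicity, read by WST assay, with a stated time of 48 h; a lower number here means that less compound is needed, a higher number that more compound is needed for the effect:
- compound 1 `O=C1OC[C@H](Cc2ccccc2)[C@H]1Cc1cccc(F)c1` gives 75000 nM
- compound 2 `COc1ccc(C[C@H]2C(=O)OC[C@@H]2Cc2ccccc2)cc1` gives 67000 nM
- compound 3 `COCOc1ccc(C[C@H]2C(=O)OC[C@@H]2Cc2ccccc2)cc1` gives 71000 nM

Compound 3 stands within the scatter of both compound 1 and compound 2, so the three numbers give no order. Compound 4 `O=C1OC[C@H](Cc2ccccc2)[C@H]1Cc1ccc(Cl)cc1` follows from compound 3 with one change, chloro in place of methoxymethoxy on an aromatic carbon. Going by the values given here, the one measured step at this place is a 1.1-fold higher number from compound 2 to compound 3 (0.03 log units; within the scatter), which shows no response to the group there. Among the compounds with values here, no chloro compound has been measured. Compound 1, with its fluoro group, gives 75000 nM in the same range. No step beyond the scatter is therefore expected in this assay. The expected step is a 1.2-fold lower number from compound 3 to compound 4 (0.07 log units; within the scatter). Compound 4 is estimated at 60000 nM, within an expected range of 25000 nM to 110000 nM.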

Compound 4, half-maximal effective concentration: 36000 nM
For compound 4 the middle estimate is 1.7-fold (0.22 log units) above the measured one; the range from low to high includes it.
By their numbers in this assay, from the lowest: compounds 4, 2, 3 and 1 (each within the scatter of the next, the first and the last beyond it).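

Chloro in place of methoxymethoxy gives a 2.0-fold lower number from compound 3 to compound 4 (0.29 log units; within the scatter), and chloro in place of methoxy gives a 1.9-fold lower number from compound 2 to compound 4 (0.27 log units; within the scatter), so in this assay both steps at this aromatic carbon stay within the scatter. Only 4-chlorophenyl in place of 3-fluorophenyl gives a step modestly beyond it, a 2.1-fold lower number from compound 1 to compound 4 (0.32 log units; beyond the scatter), the first in the series to leave the scatter. No supporting data bear on this result.

That step does not separate the identity of the halogen from where it sits. From the compounds shown here alone, whether an amine or a carboxylic acid on this aromatic carbon would give a larger step remains open.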